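The source may report more compounds than this note shows. Statements on the series, on what has been measured and on what is new or still open speak of the compounds shown alone.

Compound 1 `Cc1ccc([C@H](C(=O)N(C)C)N2C(=O)[C@@H](C3Cc4ccccc4C3)NC(=O)[C@H]2CC(C)C)cn1`: 6 mL/min/kg
Compound 2 `CC[C@H](C)[C@@H]1C(=O)N[C@H](C2Cc3ccccc3C2)C(=O)N1[C@@H](C(=O)N(C)C)c1ccc(C)nc1C`: 14 mL/min/kg

Only these two compounds have been measured in an in vivo ADME assay on the whole organism for pharmacokinetics, with Canis familiaris (Canis lupus familiaris) as the target, at a dose of 0.6 mg/kg; on this read-out higher numbers stand for fast clearance and lower numbers for slow clearance. Compound 2 stands at 14 mL/min/kg, the higher of the two numbers, and the gap down to compound 1 at 6 mL/min/kg lies beyond the usual scatter. The next case is compound 3 `CC[C@H](C)[C@@H]1C(=O)N[C@H](C2Cc3ccccc3C2)C(=O)N1[C@@H](C(=O)N(C)C)c1ccc(C)[n+]([O-])c1`. Its structural change is a group of 8 heavy atoms (6 carbon, 1 nitrogen, 1 oxygen; one six-membered aromatic ring with 1 hetero atom) in place of a group of 8 heavy atoms (7 carbon, 1 nitrogen; one six-membered aromatic ring with 1 hetero atom), on a saturated chain carbon bound to an amide-type nitrogen in a ring and a carbonyl carbon, with the 2,6-dimethylpyridin-3-yl group of compound 2 being replaced. For the measured compounds named here, no measured pair isolates this change, so the expectation is only tentative. It leans on compound 1 at 6 mL/min/kg, which shows a lower number within reach. A moderate downward move, slightly beyond the scatter, is expected, and this estimated step is a 2.3-fold lower number from compound 2 to compound 3 (0.37 log units; beyond the scatter). For compound 3 the estimated clearance is 6 mL/min/kg, with an expected range from 2.5 mL/min/kg to 14 mL/min/kg.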

Compound 3, clearance: 14 mL/min/kg
For compound 3 the middle estimate is 2.3-fold (0.37 log units) below the measured one; measured number inside the range.
By their numbers in this assay, from the lowest: compound 1; then compounds 2 and 3 (each within the scatter of the next).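

In this assay, for the compounds shown here, this pair gives the first step that isolates a single change. At the saturated chain carbon bound to an amide-type nitrogen in a ring and a carbonyl carbon, putting a group with no common name in place of the 2,6-dimethylpyridin-3-yl group gives no change at the digits printed from compound 2 to compound 3 (within the scatter) and does not separate the two compounds on clearance. The swap leaves the counted hydrogen-bond donors and acceptors and the absence of net charge as they were, and no supporting measurement bears on this result. What the compounds shown leave open is whether a group carrying a carboxylic acid or a primary amine at this place would shift clearance beyond the scatter. They also leave open whether this result would hold on a different shared core.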